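From nitro to ethoxy on a shared core

The source may hold more compounds than are shown below. What is called first, only, known or untested is meant among the compounds shown, and "the series" means these compounds.

Values in a functional assay on ASPC1 cells (Homo sapiens) for cytotoxicity (on this read-out higher numbers stand for weaker inhibition and lower numbers for stronger inhibition), for the measured compounds
Compound 1 `CS(=O)(=O)c1ccc2nc(NC(=O)CCCCCCC(=O)NO)sc2c1` gives 13.5 ug/mL
Compound 2 `Cc1ccc2nc(NC(=O)CCCCCCC(=O)NO)sc2c1` gives 0.54 ug/mL
Compound 3 `O=C(CCCCCCC(=O)Nc1nc2ccc([N+](=O)[O-])cc2s1)NO` gives 1.65 ug/mL

Compound 3 gives 1.65 ug/mL and stands second highest of the three numbers, below compound 1 and above compound 2. The next change leads to compound 4 `CCOc1ccc2nc(NC(=O)CCCCCCC(=O)NO)sc2c1` and is counted as ethoxy in place of nitro on an aromatic carbon with ethoxy in place of nitro on an aromatic carbon.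

All three measured steps change the group on this same aromatic carbon. The nearest in kind is the modest 3.1-fold higher number from compound 2 to compound 3 (0.49 log units; beyond the scatter) for nitro in place of methyl. The modest 8.2-fold lower number from compound 1 to compound 3 (0.91 log units; beyond the scatter) and the large 25-fold lower number from compound 1 to compound 2 (1.40 log units; beyond the scatter) show how far the number can move with the group at this carbon. For the measured compounds named here, no measured compound carries ethoxy, so the direction rests on a judgement: ethoxy is taken to sit closer to the methyl of compound 2 at 0.54 ug/mL than to the nitro of compound 3.

A small move to a lower number is therefore expected, smaller than the step between compound 2 and compound 3. The expected change is a 2.2-fold lower number from compound 3 to compound 4 (0.34 log units; beyond the scatter) in this assay and it may barely clear the scatter. For compound 4 the estimate is 0.75 ug/mL with an expected range from 0.25 ug/mL to 2.2 ug/mL on this read-out.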

Compound 4, half-maximal inhibitory concentration: 9.88 ug/mL
The estimate for compound 4 lay 13-fold (1.12 log units) below the measured number, outside the stated range (above it).
By their numbers in this assay, from the lowest: compound 2; then compound 3; then compounds 4 and 1 (each within the scatter of the next).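

In this assay ethoxy does not behave like methyl at this aromatic carbon: the change brings an 18-fold higher number from compound 2 to compound 4 (1.26 log units; beyond the scatter) and, measured against nitro, a 6.0-fold higher number from compound 3 to compound 4 (0.78 log units; beyond the scatter) even though ethoxy and nitro are counted with the same number of heavy atoms. Ethoxy instead cannot be told apart from methylsulfonyl, with a 1.4-fold lower number from compound 1 to compound 4 (0.14 log units; within the scatter) as the step between them, so among these four groups compound 2 alone gives the lowest number, compound 3 stands in the middle, and compounds 4 and 1 share the high end. No information is available here that would explain why the oxygen-linked chain of compound 4 lands with methylsulfonyl rather than with methyl.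

The compounds shown leave open whether the high number of compound 4 belongs to the ether oxygen or to the two carbons attached to it, a question that methoxy or a plain ethyl group at the same carbon would address. They also leave open where an amine or a chlorine at this carbon would fall among these four groups.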